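The compounds below may be only part of what the source reports. "The series", "measured", "known", "first", "only" and "open" are said of these compounds alone.

The shared core appears in compound 1 `COC(=O)/C=C/c1cccc(N(Cc2ccc(/C=C/c3c(Cl)cccc3Cl)cc2)C(=O)C(C)C)c1`, compound 2 `COC(=O)/C=C/c1cccc(N(Cc2ccc(-c3ccc(OC)cc3)cc2)C(=O)C2CCCCC2)c1` and compound 3 `COC(=O)/C=C/c1cccc(N(Cc2ccc(-c3cccc(C)c3)cc2)C(=O)C2CCCCC2)c1`. In an assay on isolated protein with Bile acid receptor (Homo sapiens) as the target (a lower number here means that less compound is needed, a higher number that more compound is needed for the effect), compound 1 gives 195 nM, compound 2 gives 89 nM and compound 3 gives 109 nM. Compound 1 thus stands at the highest of the three numbers; its gap to compound 3 lies within the scatter, while its gap to compound 2 lies beyond it. Among the compounds with values here, the only step between measured compounds that differ in one place is a 1.2-fold higher number from compound 2 to compound 3 (0.09 log units; within the scatter), a swap on the outer ring that leaves the number essentially unchanged. Compound 4 `COC(=O)/C=C/c1cccc(N(Cc2ccc(-c3ccc(OC(F)(F)F)cc3)cc2)C(=O)C(C)C)c1` has not yet been measured. It differs from compound 1 in one place: 4-(trifluoromethoxy)phenyl in place of 2-(2,6-dichlorophenyl)ethenyl on an aromatic carbon. Within the data shown here, no measured step covers this change directly. Compounds 2 and 3, which carry 4-methoxyphenyl and 3-methylphenyl where compound 1 carries the ethenyl-linked group, give the two lower numbers, but each also differs from compound 1 elsewhere, so their values speak only loosely for the change. From them a modest shift toward a lower number is expected, a 1.6-fold lower number from compound 1 to compound 4 (0.21 log units; within the scatter), with wide uncertainty. Compound 4 is therefore estimated at 120 nM in this assay, within a range from 45 nM to 350 nM.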

Compound 4, half-maximal effective concentration: 219 nM
Beside the measured number, compound 4's estimate is 1.8-fold (0.26 log units) below it, within the range that was stated.
By their numbers in this assay, from the lowest: compounds 2, 3, 1 and 4 (each within the scatter of the next, the first and the last beyond it).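

In this assay, putting 4-(trifluoromethoxy)phenyl in place of 2-(2,6-dichlorophenyl)ethenyl on an aromatic carbon, para to a large group, gives a 1.1-fold higher number from compound 1 to compound 4 (0.05 log units; within the scatter). This is the first step shown at this position with everything else in compound 1 held fixed, and it replaces one outer ring carrying two chlorine atoms on an ethenyl link with a directly attached ring carrying a trifluoromethoxy group, yet the two numbers cannot be told apart. The exchange removes the double bond outside the aromatic rings and adds a hydrogen-bond acceptor, so in this one pair neither difference comes with a shift beyond the scatter, and nothing available here offers an explanation for that result.

From the compounds shown here alone, what stays open is whether this position would read the same with a group of another kind, such as an amine or a carboxylic acid on the outer ring, or a longer chain in place of that ring. The compounds shown also leave open whether the same exchange would give a similar step on the amide carried by compound 2 and compound 3.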